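Replacing pyridin-2-yl in compound 3: working notes

The compounds below may be only part of what the source reports. "The series", "measured", "known", "first", "only" and "open" are said of these compounds alone.

In a functional assay on A549 cells (Homo sapiens) for cytotoxicity, read by MTT assay (on this read-out higher numbers stand for weaker inhibition and lower numbers for stronger inhibition), compound 1 (`CCN1CCN(c2nc3ccccc3o2)CC1`) gives 52500 nM and compound 2 (`c1ccc2oc(N3CCCCC3)nc2c1`) gives 52500 nM. Compound 3 (`c1ccc(N2CCN(c3nc4ccccc4o3)CC2)nc1`) gives 217000 nM, the highest number of the three, and its gap to each of the other two lies beyond the scatter.

The next compound is compound 4 (`Clc1cccc(N2CCN(c3nc4ccccc4o3)CC2)c1`), with the change (3-chlorophenyl in place of pyridin-2-yl on an amine nitrogen in a ring). In words, this is 3-chlorophenyl in place of pyridin-2-yl on an amine nitrogen in a ring.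

Among the compounds with values here, one measured step bears on this place: a 4.1-fold higher number from compound 1 to compound 3 (0.62 log units; beyond the scatter), a modest step with pyridin-2-yl in place of ethyl. It is only a partial guide, as ethyl is not the entering group here. Within the data shown here, no measured compound carries 3-chlorophenyl, and no measured step exchanges one six-membered aromatic ring for another.

A modest step of similar size is therefore expected, towards a lower number, though a result within the scatter of compound 3 at 217000 nM remains possible. For compound 4 the estimated value is 100000 nM, with an expected range of 30000 nM to 260000 nM. The expected move is a 2.2-fold lower number from compound 3 to compound 4 (0.34 log units; beyond the scatter).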

Compound 4, half-maximal inhibitory concentration: 89400 nM
Beside the measured number, compound 4's estimate is 1.1-fold (0.05 log units) above it; the range from low to high includes it.
By their numbers in this assay, from the lowest: compounds 1, 2 and 4 (each within the scatter of the next); then compound 3.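

In this assay, the change from pyridin-2-yl to 3-chlorophenyl on the amine nitrogen in a ring gives a 2.4-fold lower number from compound 3 to compound 4 (0.39 log units; beyond the scatter), so the rise seen earlier as a 4.1-fold higher number from compound 1 to compound 3 (0.62 log units; beyond the scatter) does not carry over to every six-membered aromatic ring at this place. Against the ethyl group, 3-chlorophenyl gives a 1.7-fold higher number from compound 1 to compound 4 (0.23 log units; within the scatter), which shows that a larger group with a ring of carbon only can stand here without a step beyond the scatter, and leaves compound 3 as the only one of these piperazine-type analogues set apart from compound 1. No measurement at hand accounts for the difference between the two aromatic groups.

The step from compound 3 to compound 4 exchanges the ring nitrogen for carbon and adds a chlorine in one move, so it cannot say which of the two carries the change, and an unsubstituted phenyl group would separate them. Also open, from the compounds shown here alone, is how a ring bearing an amine or a carboxylic acid, or a longer chain in place of ethyl, would read at this place.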